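Allyl to Isopropyl on the Aromatic Nitrogen

This account rests on a few compounds, and the source may have more. Where it says the series, first, only, none or still open, it means among the compounds named here.

Compound 3 `C=CCNc1nnc(SCC(=O)N(Cc2cccc([N+](=O)[O-])c2)c2ccc(F)cc2)s1` has the highest of the three numbers in an assay on isolated protein for inhibition of Amine oxidase [flavin-containing] A (Homo sapiens), read by fluorescence and Amplex Red, with a stated time of 30 min, tested at 0.1 nM (a higher number here means a stronger effect of the compound at the concentration tested, a lower number a weaker effect), giving 13.5%, although all three lie within the scatter of one another: compound 2 `CC(C)CNc1nnc(SCC(=O)N(Cc2cccc([N+](=O)[O-])c2)c2ccc(F)cc2)s1` gives 12.6% and compound 1 `CCCNc1nnc(SCC(=O)N(Cc2cccc([N+](=O)[O-])c2)c2ccc(F)cc2)s1` gives 12%. Compound 4 `CC(C)Nc1nnc(SCC(=O)N(Cc2cccc([N+](=O)[O-])c2)c2ccc(F)cc2)s1` differs from compound 3 by isopropyl in place of allyl on a nitrogen on an aromatic ring. Two measured steps change the same place, a number 1.5 percentage points higher from compound 1 to compound 3 (within the scatter) and a number 0.9 percentage points higher from compound 2 to compound 3 (within the scatter), and a third, a number 0.6 percentage points higher from compound 1 to compound 2 (within the scatter), also stayed within the scatter. Each change to this chain left the assay essentially unmoved, so no step beyond the scatter is expected from this one either, and the expected step is a number 0.5 percentage points lower from compound 3 to compound 4 (within the scatter). Compound 4 is therefore estimated at 13%, with a range from 8% to 18%.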

Compound 4, a percentage reported as inhibition, at one concentration (the size of the read-out at that concentration, not a potency): 10.8%
For compound 4 the middle estimate is 2.2 percentage points above the measured one, and the stated range covers the measured number.
By their numbers in this assay, from the lowest: compounds 4, 1, 2 and 3 (each within the scatter of the next).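

Isopropyl on a nitrogen on an aromatic ring also leaves this assay within the scatter of the other three chains, with a number 2.7 percentage points lower from compound 3 to compound 4 (within the scatter), a number 1.8 percentage points lower from compound 2 to compound 4 (within the scatter) and a number 1.2 percentage points lower from compound 1 to compound 4 (within the scatter). This place therefore accepts this branched chain as well as propyl, isobutyl and allyl, with all four compounds level at this single concentration. Nothing available explains these small differences.

Going by these compounds, whether a more different group here, such as a carboxylic acid, a primary amine or a phenyl ring, would move the number stays open. Also open, on these data alone, is whether these four compounds would separate at higher concentrations.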